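A few compounds are considered here, and "the series" means these few. Any claim that something is new, unique, unknown or untested is made for them only; others in the source may bear on it.

In a functional assay on HeLa cells (Homo sapiens) for antiproliferative activity, read by MTT assay, with a stated time of 24 h (on this read-out lower numbers stand for stronger inhibition and higher numbers for weaker inhibition), compound 2 `Cc1ccc(-c2nn(-c3ccccc3)cc2-c2nc3ccccc3n2S(=O)(=O)c2ccc(C)cc2)cc1` gives 480 nM, the lower of the two numbers recorded so far, while compound 1 `FC(F)(F)c1ccc(-c2nn(-c3ccccc3)cc2-c2nc3ccccc3[nH]2)cc1` gives 4670 nM, a gap that lies beyond the usual scatter. Compound 3 `Cc1ccc(-c2nn(-c3ccccc3)cc2-c2nc3ccccc3n2S(=O)(=O)c2ccc(Cl)cc2)cc1` has not yet been measured; it differs from compound 2 in a single place: chloro in place of methyl on an aromatic carbon. Among the compounds with values here, no measured pair shows this exchange, so the step expected from compound 2 to compound 3 in this assay is small, in either direction, and may not exceed the scatter: a 1.1-fold lower number from compound 2 to compound 3 (0.03 log units; within the scatter). For compound 3 the estimated value is 450 nM, within a range from 200 nM to 1000 nM.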

Compound 3, half-maximal inhibitory concentration: 4060 nM
Estimate against measurement, compound 3: 9.0-fold (0.96 log units) below; the measured number lies above the stated range.
By their numbers in this assay, from the lowest: compound 2; then compounds 3 and 1 (each within the scatter of the next).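

In this assay, chloro in place of methyl on the aromatic carbon of the (4-methylphenyl)sulfonyl group costs a great deal of inhibition (an 8.5-fold higher number from compound 2 to compound 3 (0.93 log units; beyond the scatter)). The exchange leaves the heavy-atom count unchanged, yet this single substitution on the ring, para to a large group, changes the read-out beyond the scatter. Nothing available here accounts for the size of the step. The compounds shown leave open how a methoxy group, an amine or a bare hydrogen would read at this place. They also leave open whether the same exchange would give a similar step on a different core.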